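The source may hold more compounds than are shown below. What is called first, only, known or untested is meant among the compounds shown, and "the series" means these compounds.

In an ADME assay on Raji cells (Homo sapiens) for cytotoxicity, with a stated time of 72 h (on this read-out lower numbers stand for an effect already at smaller amounts and higher numbers for an effect only at larger amounts of compound), compound 1 (`Cc1cc(NC(=O)Nc2ccc(Cl)c(Cl)c2)c2ccccc2n1`) gives 10000 nM. Compound 2 (`CCc1ccc(NC(=O)Nc2cc(C)nc3ccccc23)cc1`) is reported in this assay only as a limit, > 25000 nM. Of these two, therefore, only compound 1 has an actual number, and compound 2 offers no exact starting point for the next comparison.

Compound 3 (`Cc1cc(NC(=O)Nc2ccc(F)cc2)c2ccccc2n1`) has not yet been measured. It differs from compound 2 in one place: fluoro in place of ethyl on an aromatic carbon, with fluoro in place of ethyl on an aromatic carbon, para to a large group. Going by the values given here, no measured pair of compounds differing in one place is available to gauge such a change directly. A modest step toward lower numbers is therefore expected in this assay, although it may prove to be no larger than the scatter. Among the compounds with values here, the only measured number available as a guide is compound 1 at 10000 nM, and compound 3 is expected to remain in the same high concentration range. The estimated change is an at least 1.2-fold lower number from compound 2 to compound 3 (0.09 log units; that floor lies within the scatter). For compound 3, the expected value is 20000 nM, with an estimated range of 8000 nM to 50000 nM.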

Compound 3, half-maximal effective concentration: > 25000 nM
Compound 3 was reported as a limit; the forecaster's own chance of this, stated with the estimate: 55%; middle value at least 1.2-fold (0.09 log units) from the limit.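

In this assay, going by these compounds alone, compound 2 and compound 3 are both reported only as limits, so no step between them can be read. Both stand at the same limit: the limit of > 25000 nM in this assay, at which 2 of the 3 values shown sit. The compounds shown leave open what actual number either compound would give, and whether fluoro in place of ethyl changes it at all.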